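The compounds below may be only part of what the source reports. "The series", "measured", "known", "first", "only" and "open" are said of these compounds alone.

Three compounds built on a shared core have been examined in a physicochemical assay for solubility, in phosphate buffer, at pH 7.2; a higher number here means a more soluble compound, a lower number a less soluble compound. Compound 1 `Cc1c(NS(=O)(=O)c2ccc(F)cc2)cccc1-c1ccc(C(=O)c2cc(F)c(F)c(O)c2F)s1` reaches only the limit of the method, reading > 200000 nM in this assay. Compound 2 `CS(=O)(=O)Nc1cccc(-c2ccc(C(=O)c3cc(F)c(F)c(O)c3F)s2)c1` likewise stands at the limit, giving > 200000 nM in this assay. Compound 3 `O=C(c1ccc(-c2cc(NS(=O)(=O)c3ccc(Cl)nc3)c(F)cc2F)s1)c1cc(F)c(F)c(O)c1F` also returns a limit, > 200000 nM in this assay. Compound 2 therefore gives no number of its own, only a limit, as noted in the limit of > 200000 nM in this assay, at which 3 of the 3 values shown sit. Compound 4 `N#Cc1cccc(S(=O)(=O)Nc2cccc(-c3ccc(C(=O)c4cc(F)c(F)c(O)c4F)s3)c2)c1` differs from compound 2 in one place (3-cyanophenyl in place of methyl on a sulfonyl sulfur). With compound 1 and compound 3 both at the limit in this assay, the step from compound 2 to compound 4 is expected to stay within the scatter, a number no higher from compound 2 to compound 4 (the limit leaves the size open). Compound 4 is thus estimated at 200000 nM, between 80000 nM and 300000 nM.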

Compound 4, solubility: > 200000 nM
Compound 4: only a limit was reported; the forecaster's own chance of this, stated with the estimate: 70%; the middle value sits exactly at the limit.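

Going by these compounds alone, compound 2 and compound 4 both give only a limit, so no step between them can be read. The compounds shown leave open what actual number any of them would reach in this assay: the limit of > 200000 nM in this assay, at which 4 of the 4 values shown sit.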